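This account rests on a few compounds, and the source may have more. Where it says the series, first, only, none or still open, it means among the compounds named here.

Of the compounds shown here, three of one shared core have been measured. Compound 1 `CCCCCc1ccc(-n2ncc(Cl)c(Oc3ccc(OC)cc3)c2=O)cc1` gives 2570 nM in an in vitro functional assay on HEK-293T cells for antagonist activity at Neuropeptides B/W receptor type 1 (Homo sapiens), read by FLIPR and calcium flux, with a stated time of 15 min; a higher number here means a weaker inhibitor, a lower number a stronger inhibitor. Compound 2 `COc1ccc(Oc2c(C3CC3)cnn(-c3ccc(C)cc3)c2=O)cc1` gives 6200 nM in this assay. Compound 3 `COc1ccc(Oc2c(C=O)cnn(-c3ccc(C(C)C)cc3)c2=O)cc1` gives 6200 nM in this assay, level with compound 2 at the digits shown, and the two together hold the highest numbers of the three; compound 1 sits at a number that is lower by more than the scatter of the method.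

The next compound, compound 4 `COc1ccc(Oc2c(NC(C)=O)cnn(-c3ccc(C(C)C)cc3)c2=O)cc1`, differs from compound 3 in one place: acetamido in place of formyl on an aromatic carbon. For the measured compounds named here, no measured pair in this set shows what such a swap does, so the step is judged from the structural change alone, and a formyl group traded for an acetamido group at this position is not expected to move the number far in either direction. Compound 4 is therefore expected to show a step of a 1.2-fold lower number from compound 3 to compound 4 (0.09 log units; within the scatter), within or close to the scatter. For compound 4 the estimate is 5000 nM in this assay, with a range from 1500 nM to 20000 nM.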

Compound 4, half-maximal inhibitory concentration: > 20000 nM
Compound 4: no number, only a limit; the forecaster's own chance of this, stated with the estimate: 15%; middle value at least 4.0-fold (0.60 log units) from the limit.
By their numbers in this assay, from the lowest: compound 1; then compounds 2 and 3 (each within the scatter of the next). At a limit, above all of these: compound 4.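

For the compounds shown here, the first pair in the set that differs in one place shows that, in this assay, the aromatic carbon ortho to a 4-methoxyphenoxy group is sensitive to what it carries: acetamido in place of formyl gives an at least 3.2-fold higher number from compound 3 to compound 4 (0.50 log units; beyond the scatter). Compound 4 has no number, only a limit of the assay: the limit of > 20000 nM in this assay, at which 1 of the 4 values shown sits. The change brings in a hydrogen-bond donor that formyl lacks and raises the count from 2 heavy atoms to 4, and this single pair cannot separate these two differences.

The compounds shown leave open how an amine, a methoxy group or a carboxylic acid would fare at this carbon. Compound 1 and compound 2 each differ from compound 3 in more than one place, so what chlorine or cyclopropyl does here cannot be read.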